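The source may hold more compounds than are shown below. What is called first, only, known or untested is meant among the compounds shown, and "the series" means these compounds.

In an ADME assay on CCRF-CEM cells (Homo sapiens) for cytotoxicity, with a stated time of 3 days (on this read-out higher numbers stand for lower toxicity in this test and lower numbers for higher toxicity in this test), compound 1 `O=C(OC1C=CC(n2ccc(=O)n(Cc3ccccc3)c2=O)C1)c1ccccc1` gives > 25000 nM, which is a limit of the assay and not a number. Compound 3 `O=c1ccn(C2C=CC(O)C2)c(=O)n1Cc1ccccc1` gives > 250000 nM, and this too is a limit. Compound 3 carries a hydrogen where compound 1 has a benzoyl on an oxygen, but a step that the two limits leave unreadable from compound 1 to compound 3 gives no size to carry forward. For the measured compounds named here, compound 2 `Cc1cc(C)cc(Cn2c(=O)cc(C)n(C3C=CC(OC(=O)c4ccccc4)C3)c2=O)c1` gives 25000 nM, the only true number among the three measured compounds.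

Compound 4 `O=C(OC1C=CC(n2ccc(=O)n(C(=O)c3ccccc3)c2=O)C1)c1ccccc1` keeps the core of compound 1 and changes one group: benzoyl in place of benzyl on an aromatic nitrogen. The one measured step between two of these compounds lies elsewhere in the molecule, on the oxygen, and its size cannot be read. Going by the values given here, no measured step therefore speaks directly to this swap. Compound 2, at 25000 nM, is the only numerical anchor, so no step beyond the scatter is expected in this assay, and no direction can be favoured. The expected step is a number no higher from compound 1 to compound 4 (the limit leaves the size open), an estimate that rests on very little. For compound 4 the estimated value is 25000 nM, with an expected range of 8000 nM to 100000 nM, and the assay may well report only a limit.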

Compound 4, half-maximal cytotoxic concentration: >= 250000 nM
Compound 4 gave a limit, no number (the forecaster's own chance of this, stated with the estimate: 50%); at least 10-fold (1.00 log units) between middle value and limit.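

In this assay compound 4 gives >= 250000 nM, which is a limit and not a number. Compound 1 gives > 25000 nM, also a limit, so the step from compound 1 to compound 4 cannot be read. The compounds shown leave open what size of change, if any, benzoyl in place of benzyl on an aromatic nitrogen brings.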